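The source may hold more compounds than are shown below. What is called first, only, known or untested is meant among the compounds shown, and "the series" means these compounds.

Measured so far:
compound 1, `CC1=CC[C@@H]([C@@](C)(O)CCCC(C)(C)NC(=S)NN)CC1` — > 100000 nM
compound 2, `CC1=CC[C@@H]([C@@](C)(O)CCCC(C)(C)NC(=S)N/N=C\c2ccccc2[N+](=O)[O-])CC1` — 16800 nM

In a functional assay on HT-29 cells (Homo sapiens) for cytotoxicity, read by sulforhodamine B assay (a lower number here means a stronger inhibitor of growth, a higher number a weaker inhibitor of growth), compound 1 reaches only a limit of the assay, > 100000 nM; this is the limit of > 100000 nM in this assay, at which 1 of the 2 values shown sits. In this assay, among the compounds with values here, compound 2 gives 16800 nM, the only real number so far, so nothing ranks it against another compound. Compound 3 `CC1=CC[C@@H]([C@@](C)(O)CCCC(C)(C)NC(=S)N/N=C\c2ccccc2Cl)CC1` differs from compound 2 by chloro in place of nitro on an aromatic carbon. Within the data shown here, no measured pair covers this change, so only a small step is expected, within the scatter, with no preferred direction. Compound 3 is therefore estimated at 20000 nM, range 5000 nM to 80000 nM, an expected step of a 1.2-fold higher number from compound 2 to compound 3 (0.08 log units; within the scatter).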

Compound 3, concentration for total growth inhibition: > 100000 nM
Compound 3: no number, only a limit; the forecaster's own chance of this, stated with the estimate: 15%; middle value at least 5.0-fold (0.69 log units) away from the limit.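

Chloro in place of nitro on this aromatic carbon is not a neutral exchange in this assay: the change gives an at least 5.9-fold higher number from compound 2 to compound 3 (0.77 log units; beyond the scatter) and separates the two compounds beyond the scatter. As far as these compounds go, compound 3 gives only a limit, so the true size of the step stays unknown. The step between compound 1 and compound 3 cannot be read, and compound 2 remains the only compound with a real number: the limit of > 100000 nM in this assay, at which 2 of the 3 values shown sit.

The compounds shown leave open whether any other group on this aromatic carbon, such as an amine or a nitrile, gives a real number. They also leave open whether a group in place of nitro can give a lower number than compound 2.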